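The source may report more compounds than this note shows. Statements on the series, on what has been measured and on what is new or still open speak of the compounds shown alone.

Three analogues sharing one core have been examined in an assay on membranes from HeLa cells for displacement of a labelled ligand from adenosine receptor A3 (Homo sapiens), read by scintillation counting, with a stated time of 180 min, tested at 1 uM; on this read-out lower numbers stand for less inhibition and higher numbers for more inhibition at the one concentration tested (going by the name of the read-out). Compound 1 `CC1=C(C(=O)OCc2ccccc2)C(c2cccs2)NC(=O)N1` carries a benzyl ester and in this assay compound 1 gives 8%. Compound 2 `CC1=C(C(=O)OCC(C)C)C(c2ccoc2)NC(=O)N1C` carries an isobutyl ester and in this assay compound 2 gives 16%. Compound 3 `CCOC(=O)C1=C(C)N(C)C(=O)NC1c1cccs1` carries an ethyl ester and in this assay compound 3 gives 2%. Compound 3 and compound 1 lie within the usual scatter of each other, so no order between them can be read; compound 2 stands beyond the scatter on the higher side of compound 3. All three numbers are small, pointing to weak inhibition at the concentration tested.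

The next compound, compound 4 `CC1=C(C(=O)OCC(C)C)C(c2cccs2)NC(=O)N1C`, differs from compound 3 in a single place: isopropyl in place of methyl on a saturated chain carbon bound to an oxygen next to a carbonyl group. Compound 2 already holds the isobutyl ester and reads higher than compound 3, so a modest rise is expected, most likely staying within the scatter; the step expected is a number 8 percentage points higher from compound 3 to compound 4 (within the scatter). For compound 4 the estimate in this assay is 10%, with a range from 0% to 25%.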

Compound 4, a percentage reported as inhibition, at one concentration (the size of the read-out at that concentration, not a potency): 5%
For compound 4 the middle estimate is 5 percentage points above the measured one, within the range that was stated.
By their numbers in this assay, from the lowest: compounds 3, 4, 1 and 2 (each within the scatter of the next, the first and the last beyond it).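

In this assay, isopropyl in place of methyl on a saturated chain carbon bound to an oxygen next to a carbonyl group gives a number 3 percentage points higher from compound 3 to compound 4 (within the scatter) and so shows no readable effect of this ester change while the thiophen-2-yl group stays in place. Thiophen-2-yl in place of furan-3-yl on a saturated ring carbon, with the isobutyl ester kept, gives a number 11 percentage points lower from compound 2 to compound 4 (beyond the scatter) and so ties the higher reading of compound 2 to the ring group rather than to the ester, though only within this one pair. Nothing measured here accounts for either step.

Going by these compounds, it remains open whether furan-3-yl would give a similar step alongside an ethyl ester. A carboxylic acid or an amide in place of the ester, or a phenyl ring in place of thiophen-2-yl, could still move this low reading.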